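Aryl replacement and solubility in the aminoquinoline series

This account rests on a few compounds, and the source may have more. Where it says the series, first, only, none or still open, it means among the compounds named here.

Compound 3 `COc1cccc(CNCCCNc2ccnc3cc(-c4ccc(F)cc4)ccc23)c1O` carries 4-fluorophenyl on the shared core. In a physicochemical assay for solubility, with a stated time of 18 h, at pH 7.4 (on this read-out lower numbers stand for lower solubility and higher numbers for higher solubility), compound 3 gives 32000 nM. Compound 1 `COc1cccc(CNCCCNc2ccnc3cc(-c4ccc(C(F)(F)F)cc4)ccc23)c1O`, with trifluoromethyl in that place, gives 32000 nM in this assay, and compound 2 `COc1cccc(CNCCCNc2ccnc3cc(-c4ccccc4)ccc23)c1O`, with hydrogen there, gives 32000 nM. The three stand level with one another: no change at the digits printed from compound 1 to compound 2 (within the scatter), no change at the digits printed from compound 1 to compound 3 (within the scatter) and no change at the digits printed from compound 2 to compound 3 (within the scatter).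

Compound 4 `COc1cccc(CNCCCNc2ccnc3cc(-c4cccc5ccccc45)ccc23)c1O` is not yet measured. It differs from compound 3 by naphthalen-1-yl in place of 4-fluorophenyl on an aromatic carbon. For the measured compounds named here, none of the measured steps is of this kind: the three steps compare single substituents on one six-membered aromatic ring of carbon only, and every one of them lies within the scatter. They give no direct guide to a second fused ring entering, but they do show that the read-out in this assay has so far not moved with changes at the varied carbon. An unchanged value is therefore the default expectation, while a step beyond the scatter, most plausibly toward lower values, cannot be ruled out given that the replacement adds heavy atoms and a ring. The expected step is a 1.8-fold lower number from compound 3 to compound 4 (0.25 log units; within the scatter). Compound 4 is estimated at 18000 nM in this assay, with a range from 6000 nM to 32000 nM.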

Compound 4, solubility: 32000 nM
For compound 4 the middle estimate is 1.8-fold (0.25 log units) below the measured one, within the range that was stated.
By their numbers in this assay, from the lowest: compounds 1, 2, 3 and 4 (each within the scatter of the next).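

In this assay the steps read no change at the digits printed from compound 3 to compound 4 (within the scatter) and no change at the digits printed from compound 2 to compound 4 (within the scatter) and no change at the digits printed from compound 1 to compound 4 (within the scatter) even though this change is larger in kind than any before it, with naphthalen-1-yl bringing 10 heavy atoms and 2 six-membered aromatic rings of carbon only where 4-fluorophenyl held 7 heavy atoms and one such ring. The flat read-out at this aromatic carbon therefore no longer rests on single substituents on one ring alone, and it now also covers a second fused ring, though only for these four compounds. No data are available here that bear on why the read-out stays level across this change.

As far as these compounds go, both 4-fluorophenyl and naphthalen-1-yl carry 0 hydrogen-bond donors, 0 hydrogen-bond acceptors and no net charge, so it remains open whether an amine or a carboxylic acid on the aryl group would shift the read-out. Also open, from the compounds shown here alone, is whether a ring containing nitrogen, such as a pyridine, or naphthalen-2-yl at this same carbon would stay level with these four compounds.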